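Removing the Methyl from an Aryl Sulfonyl Amidoxime

The compounds below may be only part of what the source reports. "The series", "measured", "known", "first", "only" and "open" are said of these compounds alone.

Measured compounds:
- Compound 1, `Cc1ccc(S(=O)(=O)NC(=O)Nc2ccc(Cl)cc2)cc1`: 83 ug/mL
- Compound 2, `Cc1ccc(S(=O)(=O)N/C(=N\O)Nc2ccc(Cl)cc2)cc1`: 58 ug/mL

Both compounds were tested in a functional assay on COLO 205 cells (Homo sapiens) for cytotoxicity; on this read-out lower numbers stand for stronger inhibition and higher numbers for weaker inhibition. Compound 1 gives 83 ug/mL and compound 2 gives 58 ug/mL. Compound 2 has the lower of the two numbers, but the gap to compound 1 is within the scatter of repeated measurements, so the two cannot be told apart on these data.

Compound 3, `O=S(=O)(N/C(=N\O)Nc1ccc(Cl)cc1)c1ccccc1`, has not yet been measured. It differs from compound 2 in one place: hydrogen in place of methyl on an aromatic carbon. Cut one bond further out, the difference reads 4-methylphenyl to phenyl.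

Among the compounds with values here, no measured pair shows what removing a methyl from this ring does in this assay, so the expectation rests only on the two numbers above and on the small size of the change. A step of a 1.2-fold higher number from compound 2 to compound 3 (0.08 log units; within the scatter) is expected, that is, no change beyond the scatter, with the number staying close to that of compound 2. Compound 3 is expected to give about 70 ug/mL, within a range from 30 ug/mL to 160 ug/mL.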

Compound 3, half-maximal inhibitory concentration: 53 ug/mL
For compound 3 the middle estimate is 1.3-fold (0.12 log units) above the measured one, and the stated range covers the measured number.
By their numbers in this assay, from the lowest: compounds 3, 2 and 1 (each within the scatter of the next).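

In this assay, taking the methyl off the 4-methylphenyl group to leave phenyl gives a 1.1-fold lower number from compound 2 to compound 3 (0.04 log units; within the scatter) and so leaves the two compounds indistinguishable. Within the data shown here, this is the first direct reading of this change, and it shows that the methyl on this aromatic carbon, para to a large group, is not needed for the number seen with compound 2. No measurement at hand speaks to why the two compounds read alike.

The compounds shown leave open whether an amine, a carboxylic acid or a longer chain on this same ring carbon would move the number beyond the scatter, since only methyl and hydrogen have been seen there. Among these compounds, it is also open whether removing the methyl would read the same on the core of compound 1, which carries a carbonyl where compound 2 has its amidoxime, since this step has been seen only on the core of compound 2.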